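Thiophen-3-yl in place of 4-methylphenyl on the shared core

A few compounds are considered here, and "the series" means these few. Any claim that something is new, unique, unknown or untested is made for them only; others in the source may bear on it.

In an ADME assay on L6 cells (Rattus norvegicus) for cytotoxicity, read by resazurin assay, with a stated time of 72 h (on this read-out lower numbers stand for stronger inhibition and higher numbers for weaker inhibition), compound 1 (`Cc1ccc(C(O)(c2ccc(Cl)cc2)c2cccnc2)cc1`) gives 61000 nM, and compound 2 (`COc1ccc(C(O)(c2ccc(Cl)cc2)c2cccnc2)cc1`) gives 68100 nM. The comparison shows a 1.1-fold higher number from compound 1 to compound 2 (0.05 log units; within the scatter), so compound 1 stands level with compound 2. Compound 3 (`CS(=O)(=O)Nc1ccc(C(O)(c2ccc(Cl)cc2)c2cccnc2)cc1`) gives only a limit, > 100000 nM. The two steps that rest on this limit are an at least 1.6-fold higher number from compound 1 to compound 3 (0.21 log units; that floor lies within the scatter) and an at least 1.4-fold higher number from compound 2 to compound 3 (0.16 log units; that floor lies within the scatter).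

Compound 4 (`OC(c1ccc(Cl)cc1)(c1cccnc1)c1ccsc1`) has not yet been measured. It carries thiophen-3-yl in place of 4-methylphenyl on a saturated chain carbon bound to two aromatic carbons and an oxygen on a saturated carbon. Going by the values given here, no measured step makes this exchange. The measured steps change only a group on an aromatic carbon, so they bear on it indirectly. Since compound 2 shows a 1.1-fold higher number from compound 1 to compound 2 (0.05 log units; within the scatter) and compound 3 shows only a floor within the scatter in an at least 1.6-fold higher number from compound 1 to compound 3 (0.21 log units; that floor lies within the scatter), no change beyond the scatter is expected in this assay. The expected step is a 1.1-fold higher number from compound 1 to compound 4 (0.06 log units; within the scatter). The estimated value for compound 4 is 70000 nM, within an expected range of 38000 nM to 100000 nM.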

Compound 4, half-maximal inhibitory concentration: > 100000 nM
Compound 4: a limit, no number (the forecaster's own chance of this, stated with the estimate: 25%); middle value at least 1.4-fold (0.15 log units) from the limit.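

In this assay compound 4 gives only a limit, > 100000 nM. Unlike the earlier steps, which change only a group on an aromatic carbon, this one replaces the whole 4-methylphenyl with thiophen-3-yl on a saturated chain carbon bound to two aromatic carbons and an oxygen on a saturated carbon, and it reads as an at least 1.6-fold higher number from compound 1 to compound 4 (0.21 log units; that floor lies within the scatter), so this exchange shows no change beyond the scatter, while its true size stays unknown. Compound 4 thus sits at the same limit as compound 3: the limit of > 100000 nM in this assay, at which 2 of the 4 values shown sit.

Both of these values are limits, so no order between compound 3 and compound 4 can be read. Still open, going by these compounds, is how a cyclohexyl group on that saturated chain carbon, or an amine in place of the oxygen, would read in this assay.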